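Trifluoromethyl in place of methyl, starting from a limit

A few compounds are considered here, and "the series" means these few. Any claim that something is new, unique, unknown or untested is made for them only; others in the source may bear on it.

In a functional assay on HT-29 cells (Homo sapiens) for inhibition (a lower number here means a stronger inhibitor, a higher number a weaker inhibitor), compound 1 (`CC(=O)Oc1ccc(/C=C/c2ccc3ccccc3c2)cc1`) gives > 5000 nM, a limit and not a number. Compound 2 (`Cc1ccc(/C=C/c2ccc3ccccc3c2)cc1`) gives > 5000 nM, again only a limit. The series therefore stands at the limit of > 5000 nM in this assay, at which 2 of the 2 values shown sit, and no number is yet available for either compound. Within the data shown here, the single measured change is a step that the two limits leave unreadable from compound 1 to compound 2, which offers no size to carry forward.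

Compound 3 (`FC(F)(F)c1ccc(/C=C/c2ccc3ccccc3c2)cc1`) follows from compound 2 through (trifluoromethyl in place of methyl on an aromatic carbon), with trifluoromethyl in place of methyl on an aromatic carbon, para to a large group. Among the measured compounds shown here, no measured step gives this change a size or a direction, so none beyond the scatter is expected in this assay. The expected change is a step that the limit leaves unreadable from compound 2 to compound 3. For compound 3 the estimated value is 6000 nM, with an expected range of 2500 nM to 15000 nM.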

Compound 3, half-maximal inhibitory concentration: > 5000 nM
Compound 3: no number, only a limit; the forecaster's own chance of this, stated with the estimate: 75%; the middle value is on the limit's open side.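

Compound 1, compound 2 and compound 3 all stand at a limit and not a number, so no step among them can be read: the limit of > 5000 nM in this assay, at which 3 of the 3 values shown sit.

The compounds shown leave open how strongly each inhibits, and whether acetoxy, methyl or trifluoromethyl makes any difference.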